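Series notes: hydrogen for hydroxypyrrolidinyl in a fused bicyclic

A few compounds are considered here, and "the series" means these few. Any claim that something is new, unique, unknown or untested is made for them only; others in the source may bear on it.

Three compounds of the series have been run in an assay on isolated protein for inhibition of MAP kinase-activated protein kinase 5 (Homo sapiens), read by mobility shift assay, tested at 30 uM; on this read-out lower numbers stand for less inhibition and higher numbers for more inhibition at the one concentration tested (going by the name of the read-out). Compound 1 `Cn1nc(N)c2c(=O)[nH]c(-c3ccccn3)cc21` gives 9%, compound 3 `CC(C)(C)c1cc2nn(-c3ccccc3)c(N)c2c(=O)[nH]1` gives 2%, and compound 2 `Cc1cc2c(c(N)nn2C)c(N2CC[C@H](O)C2)n1` gives 1% in this assay. All three numbers sit close to the floor of the read-out; compound 2 cannot be separated from compound 3 or from compound 1, as both gaps lie within the scatter of repeated measurements. No single-point change between two measured compounds is available, so nothing is known of how any one substituent moves this read-out.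

Compound 4 `Cc1cc2c(cn1)c(N)nn2C` is not yet measured. It differs from compound 2 in one place: hydrogen in place of 3-hydroxypyrrolidin-1-yl on an aromatic carbon. With compound 2 at 1% and the whole measured set giving small numbers, the step from compound 2 to compound 4 is expected to stay within the scatter, with no direction assigned, giving an estimated a number 2 percentage points higher from compound 2 to compound 4 (within the scatter). Compound 4 is therefore expected to show about 3% in this assay, within a range from -6% to 12%.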

Compound 4, a percentage reported as inhibition, at one concentration (the size of the read-out at that concentration, not a potency): 9%
Estimate against measurement, compound 4: 6 percentage points below; low and high end bracket the measured number.
By their numbers in this assay, from the lowest: compounds 2, 3, 1 and 4 (each within the scatter of the next).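

In this assay, among the compounds shown here, replacing 3-hydroxypyrrolidin-1-yl with hydrogen on the aromatic carbon next to the ring nitrogen gives a number 8 percentage points higher from compound 2 to compound 4 (within the scatter) and is the only single-place comparison so far. The whole group, with its ring and defined stereocentre, can therefore go from this position without a step that stands clear of the scatter. At the one concentration tested, the read-out does not separate the group from hydrogen, and both compounds remain close to its floor. No measured evidence bears on this step.

As far as these compounds go, whether a different group on this carbon, such as a primary amine, a morpholine ring or a carboxylic acid, would move inhibition clear of the scatter remains open. From the compounds shown here alone, how the methyl group on the same six-membered ring contributes also remains open.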